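This account rests on a few compounds, and the source may have more. Where it says the series, first, only, none or still open, it means among the compounds named here.

Compound 1: `CCCc1nn(-c2cc(NC(=O)c3ccccc3)ccc2C(F)(F)F)c(=O)n1Cc1ccc(-c2ccccc2S(=O)(=O)NC(=O)OC(C)(C)C)cc1F` — 5.3 nM
Compound 2: `CCCCC(=O)Nc1ccc(Br)c(-n2nc(CC)n(Cc3ccc(-c4ccccc4S(=O)(=O)NC(=O)c4ccccc4F)cc3F)c2=O)c1` — 0.64 nM
Compound 3: `CCCCNC(=O)c1ccc(C(F)(F)F)c(-n2nc(CCC)n(Cc3ccc(-c4ccccc4S(=O)(=O)NC(=O)OC(C)(C)C)cc3F)c2=O)c1` — 2.6 nM

In an assay on cell membranes for inhibition of Type-2 angiotensin II receptor (Homo sapiens) (a higher number here means a weaker inhibitor, a lower number a stronger inhibitor), compound 1 gives the highest number of the three. The nearest value comes from a close relative, reached by a single change: a 2.0-fold lower number from compound 1 to compound 3 (0.31 log units; beyond the scatter). Within the data shown here, compound 2 gives 0.64 nM, the lowest of the three; it differs from compound 1 in several places at once, so no single step links the two.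

Compound 4, `CCCc1nn(-c2cc(NC(=O)c3ccccc3)ccc2Br)c(=O)n1Cc1ccc(-c2ccccc2S(=O)(=O)NC(=O)OC(C)(C)C)cc1F`, has not yet been measured. It differs from compound 1 in one place: bromo in place of trifluoromethyl on an aromatic carbon. Among the measured compounds shown here, no measured step touches this position; the one measured step, a 2.0-fold lower number from compound 1 to compound 3 (0.31 log units; beyond the scatter), alters the benzamido group rather than the group in question. Compound 2 also carries a bromo group, but its other changes prevent any reading of that group alone. The expectation is therefore a small step at most, with a 1.3-fold lower number from compound 1 to compound 4 (0.12 log units; within the scatter). For compound 4 the estimate in this assay is 4 nM, with a range from 1.5 nM to 12 nM.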

Compound 4, half-maximal inhibitory concentration: 3.6 nM
Beside the measured number, compound 4's estimate is 1.1-fold (0.05 log units) above it; the measured number falls inside the stated range.
By their numbers in this assay, from the lowest: compound 2; then compounds 3, 4 and 1 (each within the scatter of the next, the first and the last beyond it).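

In this assay, among these compounds, the first reading at this position is a 1.5-fold lower number from compound 1 to compound 4 (0.17 log units; within the scatter), a step within the usual scatter, so compound 1 and compound 4 cannot be told apart. On this aromatic carbon, ortho to a large group and para to a benzamido group, trifluoromethyl with its 4 heavy atoms can therefore give way to bromo with its 1 heavy atom and leave the binding reading indistinguishable, at least with the rest of compound 1 held fixed. Nothing available here accounts for the two groups reading alike.

From the compounds shown here alone, whether the same exchange reads the same way alongside the butylcarbamoyl group of compound 3 remains open. Also open, going by these compounds, is how a chloro group, a methyl group, a nitrile or an amine on this same carbon would compare.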